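Swapping Phenyl for Dimethoxyphenyl on a Saturated Ring Carbon

The source may report more compounds than this note shows. Statements on the series, on what has been measured and on what is new or still open speak of the compounds shown alone.

Of the compounds shown here, three sharing one core have been tested in a functional assay on the whole organism for inhibition, with Rattus norvegicus as the target, read by paw edema, with a stated time of 3 h, at a dose of 50 mg/kg by the oral route; a lower number here means less inhibition, a higher number more inhibition at the dose given (going by the name of the read-out). Compound 2 `CS(=O)(=O)c1ccc(C2=NN(c3ccc(S(N)(=O)=O)cc3)C(c3ccccc3)C2)cc1` gives 54.3%, the highest of the three numbers. Compound 3 `CS(=O)(=O)c1ccc(C2=NN(c3ccc(S(N)(=O)=O)cc3)C(c3ccc(Cl)cc3)C2)cc1` gives 42.4%, and compound 1 `CS(=O)(=O)c1ccc(C2=NN(c3ccc(C(=O)O)cc3)C(c3cccs3)C2)cc1` gives 35.6%; compound 1 differs from compound 2 in more than one place, so its lower number cannot be tied to a single change. Within the data shown here, the only step between compounds that differ in one place, a number 11.9 percentage points lower from compound 2 to compound 3 (beyond the scatter), shows that putting chloro in place of hydrogen on an aromatic carbon cost a modest amount of inhibition. Compound 4 `COc1ccc(C2CC(c3ccc(S(C)(=O)=O)cc3)=NN2c2ccc(S(N)(=O)=O)cc2)cc1OC` differs from compound 2 as follows: 3,4-dimethoxyphenyl in place of phenyl on a saturated ring carbon. Among the measured compounds shown here, no measured step covers this exact swap, and the chloro step is only loosely comparable. A modest loss, or no step beyond the scatter, is therefore expected, and the estimate amounts to a step of a number 8.3 percentage points lower from compound 2 to compound 4 (within the scatter). Compound 4 is expected to give 46%, with a likely range from 32% to 60%.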

Compound 4, a percentage reported as inhibition, in the whole organism at one dose (the size of the read-out at that dose, not a potency): 45.5%
Beside the measured number, compound 4's estimate is 0.5 percentage points above it, within the range that was stated.
By their numbers in this assay, from the lowest: compounds 1, 3, 4 and 2 (each within the scatter of the next, the first and the last beyond it).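

In this assay, placing 3,4-dimethoxyphenyl on the saturated ring carbon brings a number 8.8 percentage points lower from compound 2 to compound 4 (within the scatter) whereas the chloro change brought a number 11.9 percentage points lower from compound 2 to compound 3 (beyond the scatter) so a substituent on this phenyl ring need not cost inhibition beyond the scatter. Against the 4-chlorophenyl group, the same change brings a number 3.1 percentage points higher from compound 3 to compound 4 (within the scatter) so this read-out does not separate these two substituted rings at this dose. Nothing at hand gives a measured reason for these numbers. Still open, going by these compounds, is whether a single methoxy group, an amine or a carboxylic acid on this phenyl ring would also stay within the scatter of compound 2. On these data alone, these are also readings at one dose and one time, so how the potencies of compound 2 and compound 4 compare remains open.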